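A 3-aminopropyl chain replaces 4-aminocyclohexyl

A few compounds are considered here, and "the series" means these few. Any claim that something is new, unique, unknown or untested is made for them only; others in the source may bear on it.

In an ADME assay on microsomes from liver (Homo sapiens) for metabolic stability, read by LC-MS, tested at 1 uM (on this read-out higher numbers stand for fast clearance and lower numbers for slow clearance), compound 3 `N[C@H]1CC[C@H](Oc2ccc([C@H]3CC[C@]4(CC3)OOC3(O4)C4CC5CC(C4)CC3C5)cc2)CC1` gives < 7 mL.min-1.g-1, which is a limit and not a number. Compound 1 `NCCOCCOc1ccc([C@H]2CC[C@]3(CC2)OOC2(O3)C3CC4CC(C3)CC2C4)cc1` gives < 7 mL.min-1.g-1, likewise a limit. This is the limit of < 7 mL.min-1.g-1 in this assay, at which 2 of the 3 values shown sit. Compound 2 `c1cc([C@H]2CC[C@]3(CC2)OOC2(O3)C3CC4CC(C3)CC2C4)ccc1OCCCNC1CCOCC1` is the only one of the three with a number, at 10 mL.min-1.g-1.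

The measured steps say little about size. They show an at least 1.4-fold higher number from compound 1 to compound 2 (0.15 log units; that floor lies within the scatter) and an at least 1.4-fold lower number from compound 2 to compound 3 (0.15 log units; that floor lies within the scatter), and neither of these floors lies beyond the scatter. The third comparison is a step that the two limits leave unreadable from compound 1 to compound 3.

Compound 4 `NCCCOc1ccc([C@H]2CC[C@]3(CC2)OOC2(O3)C3CC4CC(C3)CC2C4)cc1` is the next to be read, and it differs from compound 3 as follows: 3-aminopropyl in place of 4-aminocyclohexyl on an oxygen on an aromatic ring. In words, 3-aminopropyl stands in place of 4-aminocyclohexyl on an oxygen on an aromatic ring, and the ring of that group is lost.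

No measured step beyond the scatter bears on this change, so none beyond the scatter is expected. That expectation rests on compound 1 and compound 3 sharing (the limit of < 7 mL.min-1.g-1 in this assay, at which 2 of the 3 values shown sit). The assay may well report only a limit again. The expected outcome is a step that the limit leaves unreadable from compound 3 to compound 4. For compound 4 the estimate is 6 mL.min-1.g-1, with an expected range from 3 mL.min-1.g-1 to 13 mL.min-1.g-1.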

Compound 4, intrinsic clearance in microsomes: < 7 mL.min-1.g-1
Compound 4: no number, only a limit (the forecaster's own chance of this, stated with the estimate: 65%); the middle value does not contradict the limit.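

At this oxygen on an aromatic ring, compound 4 shows that 3-aminopropyl, which has no ring, also gives a limit and not a number, as 4-aminocyclohexyl does in compound 3, so the ring of that group is not needed for a limit to be read here. Among these compounds, the one readable new step is an at least 1.4-fold lower number from compound 2 to compound 4 (0.15 log units; that floor lies within the scatter), with hydrogen in place of oxan-4-yl on an amine nitrogen, and a floor of that size does not establish a real difference in this assay. The steps to compound 4 from compound 3 and from compound 1 cannot be read, and compound 4 joins the compounds reported only as limits: the limit of < 7 mL.min-1.g-1 in this assay, at which 3 of the 4 values shown sit.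

On these data alone, how compound 1, compound 3 and compound 4 truly rank remains open, since none of them has a number in this assay. Also open, as far as these compounds go, is whether a carboxylic acid or a tertiary amine in place of the primary amine of 3-aminopropyl would give a number rather than a limit.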